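Removing the Cyclohexyl Side Chain from an Amino Amide

A few compounds are considered here, and "the series" means these few. Any claim that something is new, unique, unknown or untested is made for them only; others in the source may bear on it.

Compound 3 `N[C@@H](C(=O)Nc1cc2cc[nH]c(=O)c2cc1Cl)C1CCCCC1` has in a functional assay (aorta) with Rattus norvegicus as the target (on this read-out higher numbers stand for an effect only at larger amounts of compound and lower numbers for an effect already at smaller amounts), only the entry "not determined" (no result reported) and no number, and compound 1 `N[C@H]1CC[C@H](C(=O)Nc2cc3cc[nH]c(=O)c3cc2Cl)CC1` likewise has only the entry "not determined" (no result reported). Going by the values given here, the only measured member of the set is compound 2 `CC(C)C[C@@H](N)C(=O)Nc1cc2cc[nH]c(=O)c2cc1Cl`, which in this assay gives 700 nM. Compound 4 `NCC(=O)Nc1cc2cc[nH]c(=O)c2cc1Cl` differs from compound 3 by hydrogen in place of cyclohexyl on a saturated chain carbon bound to an amine nitrogen and a carbonyl carbon. Among the compounds with values here, with no measured step from compound 3, the direction of this change rests only on the single value of compound 2. The loss of the whole cyclohexyl is expected to bring a step of moderate size toward weaker activity, beyond the scatter, though a step within the scatter cannot be ruled out. Compound 4 is therefore estimated at 2500 nM, with a range from 600 nM to 10000 nM.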

Compound 4, half-maximal effective concentration: 2500 nM
Beside the measured number, compound 4's estimate shows no gap at the digits printed; the measured number falls inside the stated range.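

In this assay this position now has its first readable step, a 3.6-fold higher number from compound 2 to compound 4 (0.55 log units; beyond the scatter), so the isobutyl of compound 2 goes with an effect at smaller amounts than the hydrogen of compound 4. Compound 4 shows that a number is still obtained with no side chain on this carbon. Nothing at hand gives a reason for this step. The step from compound 3 cannot be read, so cyclohexyl remains unplaced against isobutyl and hydrogen. From the compounds shown here alone, how a methyl or a phenyl on this carbon would compare also stays open.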